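The source may report more compounds than this note shows. Statements on the series, on what has been measured and on what is new or still open speak of the compounds shown alone.

Compound 1 `COCCOc1cc(C)c(-c2cccc(CNc3ccc(OCC(=O)O)c(F)c3)c2)c(C)c1` gives 51.6 nM in a functional assay on CHO cells for agonist activity at Free fatty acid receptor 1 (Homo sapiens), read by FLIPR and calcium flux; on this read-out lower numbers stand for an effect already at smaller amounts and higher numbers for an effect only at larger amounts of compound.
Compound 2 `O=C(O)COc1ccc(NCc2cccc(-c3ccccc3F)c2)cc1F` gives 36.5 nM in this assay.

Compound 2 shows the lowest of these two numbers, yet compound 1 lies within the scatter of it, so no order between them can be read. Compound 3 `CCOc1ccc(-c2cccc(CNc3ccc(OCC(=O)O)c(F)c3)c2)c(C)c1` has not yet been measured. It differs from compound 2 in one place: 4-ethoxy-2-methylphenyl in place of 2-fluorophenyl on an aromatic carbon. Within the data shown here, no measured pair differs in only one place, so this step has no direct precedent. Compound 1, which also carries a larger substituted ring on an aromatic carbon, gives 51.6 nM, close to compound 2. For compound 3 a step of a 1.2-fold higher number from compound 2 to compound 3 (0.09 log units; within the scatter) is therefore expected, not beyond the scatter, with an estimated value of 45 nM (range 15 nM to 130 nM).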

Compound 3, half-maximal effective concentration: 11.6 nM
Compound 3: the middle estimate sits 3.9-fold (0.59 log units) above what was measured, outside the stated range (below it).
By their numbers in this assay, from the lowest: compound 3; then compounds 2 and 1 (each within the scatter of the next).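

Among these compounds, on an aromatic carbon meta to a large group, 4-ethoxy-2-methylphenyl in place of 2-fluorophenyl gives a 3.1-fold lower number from compound 2 to compound 3 (0.50 log units; beyond the scatter) in this assay, the first step that lies beyond the scatter. This modest step shows that this place accepts a larger substituted ring than 2-fluorophenyl and that the number still falls. No available evidence bears on what lies behind this step. The ethoxy and the methyl entered together, and the compounds shown do not separate their shares. Going by these compounds, whether a longer chain such as propoxy, or an amine in place of the ethoxy, would keep this number remains open.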